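Taking the bromine off a weak inhibitor

The source may report more compounds than this note shows. Statements on the series, on what has been measured and on what is new or still open speak of the compounds shown alone.

In a functional assay on A549 cells (Homo sapiens) for inhibition, read by MTT assay, with a stated time of 48 h (a lower number here means a stronger inhibitor, a higher number a weaker inhibitor), compound 1 `COc1ccccc1-c1csc(N/N=C/c2ccc(F)c(F)c2)n1` gives 61300 nM and compound 2 `Fc1ccc(/C=N/Nc2nc(-c3cccc(Br)c3)cs2)cc1F` gives 16200 nM. Compound 3 `Fc1ccc(/C=N/Nc2nc(-c3ccc(Br)cc3)cs2)cc1F` reads > 100000 nM, which is a limit of the assay and not a number. Compound 4 `Fc1ccc(/C=N/Nc2nc(-c3ccccc3)cs2)cc1F` carries hydrogen in place of bromo on an aromatic carbon, para to a large group: hydrogen in place of bromo on an aromatic carbon. Within the data shown here, the steps that bear on this change are an at least 6.1-fold higher number from compound 2 to compound 3 (0.79 log units; beyond the scatter), beyond the scatter, an at least 1.6-fold higher number from compound 1 to compound 3 (0.21 log units; that floor lies within the scatter), whose floor lies within it, and a 3.8-fold lower number from compound 1 to compound 2 (0.58 log units; beyond the scatter), also beyond it. Changes on this ring therefore moved the number modestly, so a modest drop is expected. The estimated step is an at least 2.5-fold lower number from compound 3 to compound 4 (0.39 log units; beyond the scatter). Compound 4 is expected at 40000 nM, with an estimated range of 12000 nM to 100000 nM.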

Compound 4, half-maximal inhibitory concentration: 91400 nM
The estimate for compound 4 lay 2.3-fold (0.36 log units) below the measured number; the range from low to high includes it.
By their numbers in this assay, from the lowest: compound 2; then compounds 1 and 4 (each within the scatter of the next). At a limit, above all of these: compound 3.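

In this assay, the plain phenyl ring of compound 4 gives a baseline for the bromo of compound 2: taking that bromo off produces a 5.6-fold higher number from compound 2 to compound 4 (0.75 log units; beyond the scatter). Hydrogen in place of the methoxy gives a 1.5-fold higher number from compound 1 to compound 4 (0.17 log units; within the scatter), so these two compounds stand within the scatter of each other. Compound 3 stands at a limit of the assay and not at a number: the limit of > 100000 nM in this assay, at which 1 of the 4 values shown sits. Hydrogen in place of the bromo on the 4-bromophenyl gives an at least 1.0-fold lower number from compound 3 to compound 4 (0.03 log units; that floor lies within the scatter), and this floor shows no change beyond the scatter.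

Open, as far as these compounds go, is whether an amine or a carboxylic acid on this ring would bring the number below that of compound 2.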